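Varying the amino substituent on the shared core

The source may hold more compounds than are shown below. What is called first, only, known or untested is meant among the compounds shown, and "the series" means these compounds.

Compound 1 `CC(C(=O)NCc1ccc(C(F)(F)F)nc1NC1CCCCC1)c1ccc(NS(C)(=O)=O)c(F)c1`: 20.4 nM
Compound 2 `CC(C(=O)NCc1ccc(C(F)(F)F)nc1Nc1ccccc1)c1ccc(NS(C)(=O)=O)c(F)c1`: 59.6 nM
Compound 3 `CC(C(=O)NCc1ccc(C(F)(F)F)nc1NCc1ccccc1)c1ccc(NS(C)(=O)=O)c(F)c1`: 15.8 nM

All numbers come from a functional assay on CHO-K1 cells for antagonist activity at transient receptor potential cation channel subfamily V member 1 (Homo sapiens), read by FLIPR; a lower number here means a stronger inhibitor, a higher number a weaker inhibitor. Compound 3 carries the lowest number of the three, but compound 1 lies within the scatter of it (a 1.3-fold lower number from compound 1 to compound 3 (0.11 log units; within the scatter)), while compound 2 sits clearly higher (a 3.8-fold lower number from compound 2 to compound 3 (0.58 log units; beyond the scatter)); compound 3 therefore cannot be called the strongest. Compound 4 `CCCCN(C)c1nc(C(F)(F)F)ccc1CNC(=O)C(C)c1ccc(NS(C)(=O)=O)c(F)c1` carries butyl(methyl)amino in place of benzylamino on an aromatic carbon. The measured steps all swap the group on that nitrogen while keeping its hydrogen; the ring swap from compound 1 to compound 2 is modest (a 2.9-fold higher number from compound 1 to compound 2 (0.47 log units; beyond the scatter)). Among the compounds with values here, no measured step removes the donor or trades the ring for a chain. A modest rise, or none beyond the scatter, is expected: a 2.5-fold higher number from compound 3 to compound 4 (0.40 log units; beyond the scatter). Compound 4 is estimated at 40 nM, range 12 nM to 150 nM.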

Compound 4, inhibition constant: 0.8 nM
Estimate against measurement, compound 4: 50-fold (1.70 log units) above; measured number outside the range, below it.
By their numbers in this assay, from the lowest: compound 4; then compounds 3 and 1 (each within the scatter of the next); then compound 2.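

In this assay, butyl(methyl)amino on this aromatic carbon gives the largest steps in the series: a 20-fold lower number from compound 3 to compound 4 (1.30 log units; beyond the scatter) and a 26-fold lower number from compound 1 to compound 4 (1.41 log units; beyond the scatter) and a 75-fold lower number from compound 2 to compound 4 (1.87 log units; beyond the scatter). Compound 4 is the strongest inhibitor of the four and the only one here with no hydrogen on that nitrogen and no ring in the substituent, so this position holds far more potency than the ring swaps revealed. Nothing available explains the gain.

The step changes the nitrogen hydrogen and the ring together, so their shares remain unresolved. Butylamino and benzyl(methyl)amino on the shared core would separate them.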